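This account rests on a few compounds, and the source may have more. Where it says the series, first, only, none or still open, it means among the compounds named here.

Measured so far:
compound 1 `C[C@H]1CC[C@@H]2[C@@H](OC(=O)[C@]23CC(c2ccccc2)=NO3)[C@]2(C)C(=O)C=C[C@@]12O` — 39800 nM
compound 2 `C[C@H]1CC[C@@H]2[C@@H](OC(=O)[C@]23CC(c2ccc(O)cc2)=NO3)[C@]2(C)C(=O)C=C[C@@]12O` — 93000 nM

Among the measured compounds shown here, in a functional assay on DU-145 cells (Homo sapiens) for cytotoxicity, read by sulforhodamine B assay, with a stated time of 48 h (a higher number here means a weaker inhibitor, a lower number a stronger inhibitor), compound 2 stands highest of the two numbers; its nearest neighbour is compound 1, and the only step available is a 2.3-fold higher number from compound 1 to compound 2 (0.37 log units; beyond the scatter). Compound 3 `Cc1cccc(C2=NO[C@]3(C2)C(=O)O[C@@H]2[C@H]3CC[C@H](C)[C@]3(O)C=CC(=O)[C@@]23C)c1` differs from compound 2 by 3-methylphenyl in place of 4-hydroxyphenyl on a carbon with a double bond to nitrogen. For the measured compounds named here, that step bears on the removal of the hydroxy, which compound 1 shows reverses the step of compound 1 to compound 2; no measured pair speaks to the methyl. A modest fall in the number is therefore expected, a 2.3-fold lower number from compound 2 to compound 3 (0.37 log units; beyond the scatter). Compound 3 is estimated at 40000 nM, between 15000 nM and 110000 nM.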

Compound 3, half-maximal inhibitory concentration: 28000 nM
Compound 3: the middle estimate sits 1.4-fold (0.15 log units) above what was measured; low and high end bracket the measured number.
By their numbers in this assay, from the lowest: compounds 3 and 1 (each within the scatter of the next); then compound 2.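

In this assay, among the compounds shown here, methyl in place of hydrogen on the aromatic ring is the first change at this position that stays within the scatter: a 1.4-fold lower number from compound 1 to compound 3 (0.15 log units; within the scatter). The step of a 3.3-fold lower number from compound 2 to compound 3 (0.52 log units; beyond the scatter) lies beyond the scatter, so among these three compounds only compound 2, the hydroxy compound, stands apart. No measured evidence accounts for either step. Open, on these data alone, is whether 4-methylphenyl would match 3-methylphenyl, since the step from compound 2 changes both the group and its place on the ring. Also open, as far as these compounds go, is how an amine or a carboxylic acid on that ring would read.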